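Replacing 2-chlorophenyl with 4-methoxyphenyl in a small series

The compounds below may be only part of what the source reports. "The series", "measured", "known", "first", "only" and "open" are said of these compounds alone.

Of the compounds shown here, three sharing one core have been measured in a functional assay on HepG2 cells (Homo sapiens) for inhibition, read by MTT assay, with a stated time of 72 h, tested at 30 uM; on this read-out lower numbers stand for less inhibition of growth and higher numbers for more inhibition of growth at the one concentration tested. In it, compound 1 `C=CCc1ccc(OCc2cn(-c3cccc([N+](=O)[O-])c3)nn2)c(O)c1` gives 15.2%, compound 2 `C=CCc1ccc(OCc2cn(-c3ccc(C#N)cc3)nn2)c(O)c1` gives 1.5% and compound 3 `C=CCc1ccc(OCc2cn(-c3ccccc3Cl)nn2)c(O)c1` gives 2.5%. Compound 3 therefore stands within the scatter of compound 2, and beyond the scatter lower than compound 1.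

Compound 4 `C=CCc1ccc(OCc2cn(-c3ccc(OC)cc3)nn2)c(O)c1` is still unmeasured. It carries 4-methoxyphenyl in place of 2-chlorophenyl on an aromatic nitrogen. Among the measured compounds shown here, the one measured step that bears on this change sits on the same aromatic nitrogen, with 2-chlorophenyl in place of 4-cyanophenyl, and it reads a number 1 percentage points higher from compound 2 to compound 3 (within the scatter). On that evidence, no step beyond the scatter is expected in this assay, though compound 1 at 15.2% leaves some room upward. The estimated step is a number 2.5 percentage points higher from compound 3 to compound 4 (within the scatter). Compound 4 is expected to give 5%, with an estimated range from 0% to 15%.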

Compound 4, percent growth inhibition at one concentration: 15.4%
Compound 4: middle estimate off by 10.4 percentage points, on the low side, and the stated range ends below it.
By their numbers in this assay, from the lowest: compounds 2 and 3 (each within the scatter of the next); then compounds 1 and 4 (each within the scatter of the next).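

In this assay, the group on this aromatic nitrogen proves able to shift the read-out beyond the scatter: the earlier step here stayed within it, whereas 4-methoxyphenyl in place of 2-chlorophenyl gives a number 12.9 percentage points higher from compound 3 to compound 4 (beyond the scatter) and methoxy in place of cyano on an aromatic carbon gives a number 13.9 percentage points higher from compound 2 to compound 4 (beyond the scatter), both modest. Compound 4 also joins compound 1 within the scatter, so two different substituted phenyl groups now stand clear of the 2-chlorophenyl and 4-cyanophenyl compounds. Nothing available explains why the methoxy compound reads this way.

On these data alone, it remains open whether an amine, a carboxylic acid or a longer chain such as ethoxy on this phenyl ring would read with compound 4 or with compound 3. The single tested concentration also leaves open how growth inhibition by compound 4 changes with dose.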